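Quinoxaline in place of a pyrimidinedione on the piperazine arm

The source may hold more compounds than are shown below. What is called first, only, known or untested is meant among the compounds shown, and "the series" means these compounds.

Compound 2 `CCn1cc(CN2CCN(c3cccn4cc(-c5ccc(C(C)(C)C)cc5)nc34)CC2)c(=O)[nH]c1=O` gives the lowest number of the two measured here: in an assay on isolated protein for displacement of a labelled ligand from Gonadotropin-releasing hormone receptor (Homo sapiens), read by scintillation counting (a higher number here means a weaker inhibitor, a lower number a stronger inhibitor), compound 2 gives 2.3 nM, while compound 1 `CCc1nc(CN2CCN(c3cncc4[nH]c(-c5ccc(C(C)(C)C)cc5)nc34)CC2)c(C)[nH]1` gives 58 nM, a gap beyond the scatter. Compound 3 `CC(C)(C)c1ccc(-c2cn3cccc(N4CCN(Cc5cnc6ccccc6n5)CC4)c3n2)cc1` differs from compound 2 by a group of 10 heavy atoms (8 carbon, 2 nitrogen; one six-membered aromatic ring of carbon only, one six-membered aromatic ring with 2 hetero atoms) in place of a group of 10 heavy atoms (6 carbon, 2 nitrogen, 2 oxygen; one six-membered aromatic ring with 2 hetero atoms), on a saturated chain carbon bound to an amine nitrogen in a ring. Among the measured compounds shown here, no comparable step between measured compounds exists, so the size of the change is uncertain; a moderate loss, beyond the scatter, is expected, written as a 6.5-fold higher number from compound 2 to compound 3 (0.81 log units; beyond the scatter). For compound 3 the estimate in this assay is 15 nM, with a range from 3 nM to 80 nM.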

Compound 3, half-maximal inhibitory concentration: 44 nM
For compound 3 the middle estimate is 2.9-fold (0.47 log units) below the measured one; the measured number falls inside the stated range.
By their numbers in this assay, from the lowest: compound 2; then compounds 3 and 1 (each within the scatter of the next).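

In this assay, putting quinoxalin-2-yl in place of the pyrimidinedione on a saturated chain carbon bound to an amine nitrogen in a ring gives a 19-fold higher number from compound 2 to compound 3 (1.28 log units; beyond the scatter). This place therefore responds strongly to the group it carries, and two groups of 10 heavy atoms are not interchangeable there. Nothing measured here accounts for the loss.

This single step cannot separate the loss of the two carbonyl groups from the gain of the carbon-only ring. As far as these compounds go, how a plain phenyl ring or a pyridine ring would fare at this place stays open.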